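Adding 3-methoxyphenyl to a compound at the assay limit

This account rests on a few compounds, and the source may have more. Where it says the series, first, only, none or still open, it means among the compounds named here.

Compound 1 `CN(C)S(=O)(=O)c1ccccc1-c1ccc2ncnc(Nc3ccc(OCc4cccc(F)c4)c(Cl)c3)c2c1` gives > 15000 nM (a limit)
Compound 2 `COc1ccc(Nc2ncnc3ccc(-c4ccc(S(=O)(=O)N5CCOCC5)cc4)cc23)cc1Cl` gives > 15000 nM (a limit)

In an ADME assay on HepG2 cells (Homo sapiens) for cytotoxicity, read by MTT assay, with a stated time of 48 h (a higher number here means a weaker inhibitor, a lower number a stronger inhibitor), compound 2 gives > 15000 nM as a limit of the assay and not as a number. Its standing is summed up by the limit of > 15000 nM in this assay, at which 2 of the 2 values shown sit, and so the two measured compounds cannot be ranked against each other.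

Compound 3 `COc1cccc(COc2ccc(Nc3ncnc4ccc(-c5ccc(S(=O)(=O)N6CCOCC6)cc5)cc34)cc2Cl)c1` differs from compound 2 in a single place 3-methoxyphenyl in place of hydrogen on a saturated chain carbon bound to an oxygen on an aromatic ring where 3-methoxyphenyl stands in place of hydrogen on a saturated chain carbon bound to an oxygen on an aromatic ring. Cut one bond further out, the same difference reads methoxy to (3-methoxybenzyl)oxy.

Among the compounds with values here, no measured pair shows what a change of this kind does. Because of the limit of > 15000 nM in this assay, at which 2 of the 2 values shown sit, the expected step for compound 3 in this assay is none beyond the scatter, in either direction, and the assay may again report only a limit. The estimated change is a number no higher from compound 2 to compound 3 (the limit leaves the size open) and no larger. For compound 3 the estimated value is 15000 nM with an expected range from 6000 nM to 30000 nM on repeated measurement.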

Compound 3, half-maximal inhibitory concentration: > 15000 nM
Compound 3 ended at the assay's limit (the forecaster's own chance of this, stated with the estimate: 70%); the middle value sits exactly at the limit.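

Within the data shown here, compound 2 and compound 3 cannot be ranked against each other in this assay, and no step between them can be read, because each result is a limit of the assay and not a number: the limit of > 15000 nM in this assay, at which 3 of the 3 values shown sit.

The compounds shown leave open whether 3-methoxyphenyl in this place changes the result at all, and at what concentration any of the three compounds would reach half-maximal inhibition.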